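The compounds below may be only part of what the source reports. "The series", "measured", "known", "first", "only" and "open" are said of these compounds alone.

Measured so far:
Compound 1, `NC(=O)c1c(NC(=O)c2ccccc2Cl)sc2c1CCN(Cc1ccc([N+](=O)[O-])cc1)C2`: in a functional assay on HeLa cells (Homo sapiens) for antiproliferative activity, with a stated time of 24 h (a lower number here means a stronger inhibitor, a higher number a weaker inhibitor), compound 1 gives 46100 nM.
Compound 2, `CSc1ccccc1NC(=S)N1CCc2c(sc(NC(=O)c3ccccc3Cl)c2C(N)=O)C1`: in this assay compound 2 gives 43600 nM.

Going by the values given here, compound 2 stands essentially level with compound 1 on the two numbers available: the single measured step, a 1.1-fold lower number from compound 1 to compound 2 (0.02 log units; within the scatter), lies within the scatter, so neither compound can be called the stronger inhibitor. Both are weak inhibitors on this scale.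

Compound 3, `NC(=O)c1c(NC(=O)c2ccccc2Cl)sc2c1CCN(C(=S)Nc1c(Cl)cccc1Cl)C2`, keeps the shared core of compound 2 and changes only the aryl group on the thiourea: 2,6-dichlorophenyl in place of 2-(methylsulfanyl)phenyl on an amide-type nitrogen. Among the compounds with values here, the one measured step, from compound 1 to compound 2, replaces the group on the ring amine nitrogen and does not touch the aryl on the thiocarbonyl-bound nitrogen, so it does not bear directly on this change; it shows only that the series has so far stayed in one narrow band. Within the data shown here, with no informative step, the expectation for compound 3 is that it stays in that band, with a step of a 1.0-fold higher number from compound 2 to compound 3 (0.01 log units; within the scatter) that is not expected to exceed the scatter. Compound 3 is therefore estimated at 45000 nM, in the range 15000 nM to 150000 nM.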

Compound 3, half-maximal inhibitory concentration: 26500 nM
Estimate against measurement, compound 3: 1.7-fold (0.23 log units) above; the measured number falls inside the stated range.
By their numbers in this assay, from the lowest: compounds 3, 2 and 1 (each within the scatter of the next).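

In this assay the only exchange shown at this position, 2,6-dichlorophenyl in place of 2-(methylsulfanyl)phenyl on the amide-type nitrogen, gives a 1.6-fold lower number from compound 2 to compound 3 (0.22 log units; within the scatter) and so leaves compound 2 and compound 3 indistinguishable, even though the entering group has no sulfur and no hydrogen-bond acceptor. The wider exchange on the amine nitrogen in the ring, with a 1.7-fold lower number from compound 1 to compound 3 (0.24 log units; within the scatter), likewise does not separate the two compounds, so all three compounds shown remain within the scatter of one another and none can be ranked as the stronger inhibitor. No measurement on hand offers an explanation for these numbers.

The compounds shown leave open whether any aryl group on this nitrogen can move the number beyond the scatter, since they carry only two such groups and both bear substituents. A phenyl ring carrying an amine or a carboxylic acid, or a longer alkyl chain in place of the aryl ring, might or might not separate from these three compounds, and the same question stands for the rest of the shared core.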